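Triazine sulfonyl fluorides: aryl swap at the chain carbon

The source may hold more compounds than are shown below. What is called first, only, known or untested is meant among the compounds shown, and "the series" means these compounds.

Measured so far in an assay on isolated protein for inhibition of Dihydrofolate reductase (Mus musculus); on this read-out lower numbers stand for lower potency and higher numbers for higher potency (the scale is a negative logarithm):
- compound 1 `CC1(C)N=C(N)N=C(N)N1c1ccc(CC(C(=O)Nc2ccc(S(=O)(=O)F)cc2)c2cccc3ccccc23)cc1` gives 6.24
- compound 2 `CC1(C)N=C(N)N=C(N)N1c1ccc(CCCCc2ccc(Cl)cc2S(=O)(=O)F)c(Cl)c1` gives 7.82
- compound 3 `CC1(C)N=C(N)N=C(N)N1c1ccc(CCc2cc(Cl)ccc2S(=O)(=O)F)c(Cl)c1` gives 7.85

Compound 1 is the lowest of the three numbers in this assay. Its nearest neighbour is compound 2, which stands higher by a gap beyond the scatter, and compound 3 stands higher still by a gap that is also beyond the scatter. Compounds 2 and 3 lie within the scatter of each other, so nothing can be said about their order. Going by the values given here, no pair among the three differs in a single place, so no step between measured compounds is available.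

Compound 4 `COc1ccccc1C(Cc1ccc(N2C(N)=NC(N)=NC2(C)C)cc1)C(=O)Nc1ccc(S(=O)(=O)F)cc1` is the next point. It is built from compound 1 by the change (2-methoxyphenyl in place of naphthalen-1-yl on a saturated chain carbon bound to a carbonyl carbon and a saturated chain carbon). Among the compounds with values here, nothing among the measured compounds speaks to this exchange, and the only compound sharing the amide arrangement is compound 1 itself. The expectation is therefore anchored on compound 1, with a step of a number 0.04 log units lower from compound 1 to compound 4 (within the scatter) expected to be small and not beyond the scatter in either direction. Compound 4 is estimated at 6.2 in this assay, within a range from 5.5 to 6.9.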

Compound 4, logarithm of the reciprocal of the active concentration, log(1/C): 6.33
Estimate against measurement, compound 4: 0.13 log units below, and the stated range covers the measured number.
By their numbers in this assay, from the lowest: compounds 1 and 4 (each within the scatter of the next); then compounds 2 and 3 (each within the scatter of the next).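

In this assay, the series now has its first single-place comparison, a number 0.09 log units higher from compound 1 to compound 4 (within the scatter): on a saturated chain carbon bound to a carbonyl carbon and a saturated chain carbon, naphthalen-1-yl and 2-methoxyphenyl cannot be told apart. The exchange replaces two six-membered aromatic rings with one and brings in one hydrogen-bond acceptor, so neither the second ring nor the added acceptor separates the two compounds on this read-out. No measurement shown here offers an explanation for this result.

Going by these compounds alone, with only this exchange available, the separate contributions of the lost ring and the methoxy group remain unresolved, and a plain phenyl group at this carbon would be needed to divide them. Also open, on these data alone, is how far this place tolerates groups of another kind, such as a primary amine, a carboxylic acid or a longer alkyl chain in place of the aromatic group.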